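The compounds below may be only part of what the source reports. "The series", "measured", "known", "first", "only" and "open" are said of these compounds alone.

The series shares one core, carried by compound 1 `CCCCCOC(=O)N1CCN(C(=O)[C@H](CCC(=O)O)NC(=O)c2cc(N3CCC(C(=O)N(CC)CC)CC3)nc(-c3ccccc3)n2)CC1`, compound 2 `CCCCCOC(=O)N1CCN(C(=O)[C@H](CCC(=O)O)NC(=O)c2cc(N3CCC(C(=O)N4CCCC4)CC3)nc(-c3ccccc3)n2)CC1` and compound 3 `CCCCCOC(=O)N1CCN(C(=O)[C@H](CCC(=O)O)NC(=O)c2nc(-c3ccccc3)cc(N3CCC(CN)CC3)n2)CC1`. In an in vivo ADME assay on the whole organism (strain Sprague-Dawley) for pharmacokinetics, with Rattus norvegicus as the target (a higher number here means that more of the compound sits outside the plasma, a lower number that more of the compound stays in the plasma), compound 3 gives 0.28 L/kg, a number that sits within the usual scatter of compound 1 at 0.21 L/kg and of compound 2 at 0.2 L/kg. Compound 4 `CCCCCOC(=O)N1CCN(C(=O)[C@H](CCC(=O)O)NC(=O)c2nc(-c3ccccc3)cc(N3CCC(COC)CC3)n2)CC1` differs from compound 3 by methoxy in place of amino on a saturated chain carbon bound to a saturated ring carbon. The only measured step between two of these compounds is a 1.1-fold lower number from compound 1 to compound 2 (0.02 log units; within the scatter), an exchange on a carbonyl carbon elsewhere in the molecule, so no measured step speaks directly to the change from compound 3 to compound 4. With all three numbers in this assay lying close together, the expected step of a 1.2-fold lower number from compound 3 to compound 4 (0.07 log units; within the scatter) is none beyond the scatter. Compound 4 is therefore estimated at 0.24 L/kg, with a range from 0.14 L/kg to 0.4 L/kg.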

Compound 4, volume of distribution at steady state: 0.15 L/kg
Estimate against measurement, compound 4: 1.6-fold (0.20 log units) above; the range from low to high includes it.
By their numbers in this assay, from the lowest: compounds 4, 2, 1 and 3 (each within the scatter of the next).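

In this assay, going by these compounds alone, methoxy in place of amino on a saturated chain carbon bound to a saturated ring carbon gives a 1.9-fold lower number from compound 3 to compound 4 (0.27 log units; within the scatter), the only measured step at this position. Exchanging amino, with its hydrogen-bond donor, for methoxy, with none, therefore does not move the number beyond the scatter. No measurement shown accounts for this step.

On these data alone, whether a hydroxyl group, a carboxylic acid or a longer chain on this carbon would stay within the scatter remains open. Also open, as far as these compounds go, is whether any group at this position can move the number beyond it.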